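Urea series: thiazole in place of pyridine on the amide nitrogen

The source may report more compounds than this note shows. Statements on the series, on what has been measured and on what is new or still open speak of the compounds shown alone.

Compound 1 `O=C(Nc1ccncc1)Nc1cc(-c2cccnc2)cc(C(F)(F)F)c1`: in a functional assay on A549 cells (Homo sapiens) for inhibition, read by MTT assay, with a stated time of 48 h (a lower number here means a stronger inhibitor, a higher number a weaker inhibitor), compound 1 reports only a limit, > 300000 nM.
Compound 2 `COc1ccc(-c2ccc(OC(F)(F)F)c(NC(=O)Nc3ccncc3)c2)cn1`: in this assay compound 2 reports only a limit, > 300000 nM.
Compound 3 `O=C(Nc1cc(-c2cccnc2)cc(C(F)(F)F)c1)Nc1nccs1`: in this assay compound 3 gives 92100 nM.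

Compound 3 arises from compound 1 by one change, (1,3-thiazol-2-yl in place of pyridin-4-yl on an amide-type nitrogen). The resulting step is an at least 3.2-fold lower number from compound 1 to compound 3 (0.51 log units; beyond the scatter), and its size is bounded only from one side because compound 1 sits at the limit of > 300000 nM in this assay, at which 2 of the 3 values shown sit. The core of compound 2 differs from that of compound 1, but the difference between the two cores is not broken down here.

Compound 4 `COc1ccc(-c2ccc(OC(F)(F)F)c(NC(=O)Nc3nccs3)c2)cn1` arises from compound 2 by the same change, (1,3-thiazol-2-yl in place of pyridin-4-yl on an amide-type nitrogen), at the same place. For compound 4 a step of an at least 2.5-fold lower number from compound 2 to compound 4 (0.39 log units; beyond the scatter) is expected, resting on the step of an at least 3.2-fold lower number from compound 1 to compound 3 (0.51 log units; beyond the scatter) made by the same change. The expected value for compound 4 is estimated at 120000 nM, with the range from 40000 nM to 300000 nM, and a fair chance that only a limit is reported again.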

Compound 4, half-maximal inhibitory concentration: 35000 nM
Compound 4: middle estimate off by 3.4-fold (0.54 log units), on the high side; measured number outside the range, below it.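

In this assay, 1,3-thiazol-2-yl in place of pyridin-4-yl on an amide-type nitrogen gives an at least 8.5-fold lower number from compound 2 to compound 4 (0.93 log units; beyond the scatter), so the direction of the step seen on the core of compound 1 carries over to the core of compound 2. Whether the size of the step also carries over cannot be read: the same change on two cores in this assay, an at least 3.2-fold lower number (0.51 log units; beyond the scatter) from compound 1 to compound 3 and an at least 8.5-fold lower number (0.93 log units; beyond the scatter) from compound 2 to compound 4; the limit leaves it open whether they differ Both starting compounds, compound 1 and compound 2, report a limit and not a number: the limit of > 300000 nM in this assay, at which 2 of the 4 values shown sit.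

Going by these compounds, whether a different ring on the same nitrogen, such as 1,3-oxazol-2-yl or pyrimidin-2-yl, gives a step of this kind remains open. Also open, on these data alone, is which part of the difference between the two cores bears on the values.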